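The source may report more compounds than this note shows. Statements on the series, on what has been measured and on what is new or still open speak of the compounds shown alone.

Measured so far: compound 1 `COc1ccc(C(=O)N2CCC(n3cncc3-c3ccc(OS(=O)(=O)c4cccc5cnccc45)cc3)CC2)cc1`, 77 nM; compound 2 `CC(C)c1ccc(C(=O)N2CCC(n3cncc3-c3ccc(OS(=O)(=O)c4cccc5cnccc45)cc3)CC2)cc1`, 55 nM; compound 3 `CC(C)(O)c1ccc(C(=O)N2CCC(n3cncc3-c3ccc(OS(=O)(=O)c4cccc5cnccc45)cc3)CC2)cc1`, 109 nM.

In an assay on HEK293 cells for antagonist activity at P2X purinoceptor 7 (Homo sapiens), read by fluorescence, with a stated time of 2 h (a lower number here means a stronger inhibitor, a higher number a weaker inhibitor), compound 1 stands second highest of the three numbers. The steps of a 1.4-fold lower number from compound 1 to compound 2 (0.15 log units; within the scatter) and a 1.4-fold higher number from compound 1 to compound 3 (0.15 log units; within the scatter) both fall within the scatter, as does a 2.0-fold higher number from compound 2 to compound 3 (0.30 log units; within the scatter); the three compounds are not separable on these data.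

Compound 4 `CNC(=O)c1cccc(S(=O)(=O)Oc2ccc(-c3cncn3C3CCN(C(=O)c4ccc(OC)cc4)CC3)cc2)c1` differs from compound 1 by 3-(methylcarbamoyl)phenyl in place of isoquinolin-5-yl on a sulfonyl sulfur. Every measured step changes the substituent on the aromatic ring of the amide and leaves the sulfonyl aryl untouched, so none of them bears directly on this change; they show only that variation at the amide end stays within the scatter. With nothing measured at the sulfonyl position, the expectation rests on compound 1 alone and carries wide uncertainty. Compound 4 is expected to give 130 nM (range 35 nM to 500 nM). The estimated step is a 1.7-fold higher number from compound 1 to compound 4 (0.23 log units; within the scatter), expected to be small in either direction.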

Compound 4, half-maximal inhibitory concentration: 159 nM
Beside the measured number, compound 4's estimate is 1.2-fold (0.09 log units) below it; low and high end bracket the measured number.
By their numbers in this assay, from the lowest: compounds 2, 1, 3 and 4 (each within the scatter of the next, the first and the last beyond it).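

In this assay the replacement of isoquinolin-5-yl by 3-(methylcarbamoyl)phenyl on the sulfonyl sulfur gives a 2.1-fold higher number from compound 1 to compound 4 (0.31 log units; beyond the scatter) and is a modest step, the only one shown at this position. Isoquinolin-5-yl can therefore be given up for a carbon-only aromatic ring carrying a hydrogen-bond donor at this modest cost. Nothing measured here speaks to the cause of this step.

From the compounds shown here alone, it remains open whether the change of ring or the methylcarbamoyl group accounts for the step, and how a plain phenyl or a carboxylic acid on that ring would read. Going by these compounds, whether the step holds with isopropyl at the amide end is also open.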